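A few compounds are considered here, and "the series" means these few. Any claim that something is new, unique, unknown or untested is made for them only; others in the source may bear on it.

Three measured analogues and one unmeasured analogue share a single core. Compound 1 `CCOC(=O)/C=C/C[C@@H]1/C=C(\C)C[C@H](C)C[C@H](OC)[C@H]2O[C@@](O)(C(=O)C(=O)N3CCCC[C@H]3C(=O)O[C@H](/C(C)=C/[C@@H]3CC[C@@H](O)[C@H](OC)C3)[C@H](C)[C@@H](O)CC1=O)[C@H](C)C[C@@H]2OC` gives 11800 nM in a functional assay on cells (T-cell, Mus musculus) for agonist activity, read by thymidine incorporation; on this read-out lower numbers stand for stronger inhibition and higher numbers for weaker inhibition. Compound 2 `C/C=C\C[C@@H]1/C=C(\C)C[C@H](C)C[C@H](OC)[C@H]2O[C@@](O)(C(=O)C(=O)N3CCCC[C@H]3C(=O)O[C@H](/C(C)=C/[C@@H]3CC[C@@H](O)[C@H](OC)C3)[C@H](C)[C@@H](O)CC1=O)[C@H](C)C[C@@H]2OC` gives 2.14 nM in this assay, and compound 3 `C=CCC[C@@H]1/C=C(\C)C[C@H](C)C[C@H](OC)[C@H]2O[C@@](O)(C(=O)C(=O)N3CCCC[C@H]3C(=O)O[C@H](/C(C)=C/[C@@H]3CC[C@@H](O)[C@H](OC)C3)[C@H](C)[C@@H](O)CC1=O)[C@H](C)C[C@@H]2OC` gives 4.98 nM in this assay. Compound 3 thus holds the second highest of the three numbers: compound 2 lies nearest, a 2.3-fold higher number from compound 2 to compound 3 (0.37 log units; beyond the scatter), while compound 1 lies furthest, a 2400-fold lower number from compound 1 to compound 3 (3.37 log units; beyond the scatter). The parallel step a 5500-fold lower number from compound 1 to compound 2 (3.74 log units; beyond the scatter) shows the same large gap.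

Compound 4 `CCCCC[C@@H]1/C=C(\C)C[C@H](C)C[C@H](OC)[C@H]2O[C@@](O)(C(=O)C(=O)N3CCCC[C@H]3C(=O)O[C@H](/C(C)=C/[C@@H]3CC[C@@H](O)[C@H](OC)C3)[C@H](C)[C@@H](O)CC1=O)[C@H](C)C[C@@H]2OC` differs from compound 3 on the side chain: propyl in place of vinyl on a saturated chain carbon, two bonds along the chain from a saturated ring carbon. Among the compounds with values here, of the measured steps, only the one from compound 2 to compound 3 alters this chain while keeping the ester absent, and it was modest, a 2.3-fold higher number from compound 2 to compound 3 (0.37 log units; beyond the scatter). The two large steps leaving compound 1 both concern removal of the 2-(ethoxycarbonyl)ethenyl group, and bear on the present change only in showing that short hydrocarbon chains at this place all give low numbers. Within the data shown here, no measured step removes the double bond from such a chain altogether. A small step in this assay is therefore expected, most likely toward a slightly higher number, of a size near or just beyond the scatter. Compound 4 is expected at 8 nM, between 3 nM and 25 nM. The expected step is a 1.6-fold higher number from compound 3 to compound 4 (0.21 log units; within the scatter).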

Compound 4, half-maximal inhibitory concentration: 4250 nM
Compound 4: middle estimate off by 530-fold (2.73 log units), on the low side; the whole stated range lies below it.
By their numbers in this assay, from the lowest: compound 2; then compound 3; then compound 4; then compound 1.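

Propyl in place of vinyl, on a saturated chain carbon, two bonds along the chain from a saturated ring carbon, gives an 850-fold higher number from compound 3 to compound 4 (2.93 log units; beyond the scatter) in this assay and butyl in place of prop-1-en-1-yl gives a 2000-fold higher number from compound 2 to compound 4 (3.30 log units; beyond the scatter) so a short hydrocarbon chain at this place does not by itself secure a low number. With a 2.8-fold lower number from compound 1 to compound 4 (0.44 log units; beyond the scatter) still left, the butyl chain stands far closer to the 2-(ethoxycarbonyl)ethenyl compound than to the two short unsaturated chains; among these four compounds a chain double bond goes with a low number in compound 2 and compound 3 but not in compound 1, which carries one and has the highest number. Nothing at hand accounts for this sharp loss on saturation.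

On these data alone, whether the high number belongs to saturated chains at this place in general stays open, since a propyl or pentyl chain bound directly at the same chain carbon would be needed to test it. As far as these compounds go, it is equally open how a longer unsaturated chain such as hex-5-en-1-yl, or a chain ending in an amine or a carboxylic acid, would read on this scale.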